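This account rests on a few compounds, and the source may have more. Where it says the series, first, only, none or still open, it means among the compounds named here.

Working notes on the series.

Compound 1 `COCCN1C(=O)CNc2ncc(-c3ccc(C(C)(C)O)nc3)nc21`, compound 2 `CO[C@H]1CC[C@@H](N2CC(=O)Nc3ncc(-c4ccc(C(C)(C)O)nc4)nc32)CC1` and compound 3 `CO[C@H]1CC[C@H](N2C(=O)CNc3ncc(-c4ccc(C(C)(C)O)nc4)nc32)CC1` share one core and have each been measured in a functional assay on the whole organism (PC-3 cells) for inhibition, with Mus musculus as the target, in a xenograft, with a stated time of 4 h, at a dose of 100 mg/kg by the oral route; a lower number here means less inhibition, a higher number more inhibition at the dose given (going by the name of the read-out). In this assay, going by the values given here, compound 1 gives 87% and compound 3 gives 80%; the one step that differs in a single place, a number 7 percentage points lower from compound 1 to compound 3 (within the scatter), is small. Compound 2 gives 34%, the lowest of the three numbers, far from both others.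

The unmeasured compound 4 `CO[C@H]1CC[C@H](CN2CC(=O)Nc3ncc(-c4ccc(C(C)(C)O)nc4)nc32)CC1` is derived from compound 2 by (4-methoxycyclohexyl)methyl in place of 4-methoxycyclohexyl on a nitrogen on an aromatic ring in a ring. Among the compounds with values here, no measured step covers this kind of change; the only step known, a number 7 percentage points lower from compound 1 to compound 3 (within the scatter), concerns a different exchange and was within the scatter. The low reading of compound 2 shows that the common core alone does not guarantee a high number, yet nothing shown tells whether the added methylene moves the number up or down.

Compound 4 is therefore expected at 42%, with a range of 15% to 70%; the expected step is a number 8 percentage points higher from compound 2 to compound 4 (within the scatter), with no direction asserted beyond the scatter.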

Compound 4, a percentage reported as inhibition, in the whole organism at one dose (the size of the read-out at that dose, not a potency): 55%
Beside the measured number, compound 4's estimate is 13 percentage points below it, and the stated range covers the measured number.
By their numbers in this assay, from the lowest: compound 2; then compound 4; then compounds 3 and 1 (each within the scatter of the next).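

In this assay, going by these compounds alone, the exchange of 4-methoxycyclohexyl for (4-methoxycyclohexyl)methyl on a nitrogen on an aromatic ring in a ring gives a number 21 percentage points higher from compound 2 to compound 4 (beyond the scatter), the only step that lies beyond the scatter. The number at this position therefore responds to a change as small as one added methylene, with the carbon ring and its methoxy group both kept. Nothing at hand bears on why the number rises with this change.

This single step does not show whether a longer chain between the nitrogen and the ring, such as a (4-methoxycyclohexyl)ethyl group, would raise the number further or lower it again. It also leaves open how the number would move if an amine or a carboxylic acid replaced the methoxy group on the (4-methoxycyclohexyl)methyl substituent, or if that substituent sat on the amide-type nitrogen instead.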